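A few compounds are considered here, and "the series" means these few. Any claim that something is new, unique, unknown or untested is made for them only; others in the source may bear on it.

Measured so far:
compound 1, `COc1cc(CC(O)c2ccc(-c3ccc(C#N)cc3)cc2)c([N+](=O)[O-])cc1OC`: 4700 nM
compound 2, `COc1cc(CC(O)c2ccc(-c3ccc([N+](=O)[O-])cc3)cc2)c([N+](=O)[O-])cc1OC`: 21000 nM

Compound 2 gives the highest of the two numbers in an ADME assay on HeLa Rh cells (Homo sapiens) for cytotoxicity, read by microscopy; a higher number here means that more compound is tolerated, a lower number that less compound is tolerated; its nearest neighbour is compound 1, and the step of a 4.5-fold higher number from compound 1 to compound 2 (0.65 log units; beyond the scatter) lies beyond the scatter. Compound 3, `COc1cc(CC(O)c2ccc(-c3ccc(C=O)cc3)cc2)c([N+](=O)[O-])cc1OC`, has not yet been measured in this assay. It differs from compound 2 in one place: formyl in place of nitro on an aromatic carbon. Among the measured compounds shown here, only one measured step bears on this change, and only indirectly: the step of a 4.5-fold higher number from compound 1 to compound 2 (0.65 log units; beyond the scatter) shows that exchanging one small group for another on an aromatic carbon shifted the number modestly. Formyl is a third such group, so a step of similar size seems plausible, most likely back toward the lower number of compound 1. Compound 3 is therefore expected to give about 9000 nM in this assay, within 3500 nM to 23000 nM. This estimate means an expected step of a 2.3-fold lower number from compound 2 to compound 3 (0.37 log units; beyond the scatter).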

Compound 3, half-maximal cytotoxic concentration: > 245000 nM
Compound 3 ended at the assay's limit; the forecaster's own chance of this, stated with the estimate: 5%; middle value at least 27-fold (1.43 log units) away from the limit.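

Compound 3 stands at a limit of the assay, not at a measured number: the limit of > 245000 nM in this assay, at which 1 of the 3 values shown sits. In this assay, formyl on this aromatic carbon gives an at least 11-fold higher number from compound 2 to compound 3 (1.06 log units; beyond the scatter), and it gives an at least 52-fold higher number from compound 1 to compound 3 (1.71 log units; beyond the scatter). Both steps are larger than the earlier exchange of cyano for nitro, a 4.5-fold higher number from compound 1 to compound 2 (0.65 log units; beyond the scatter), so the choice of small group at this position can matter far more than compounds 1 and 2 showed, though both new steps give only a minimum size.

The compounds shown leave open whether this large change belongs to formyl alone or would also appear with a carboxylic acid, an amide or a hydroxymethyl group. They also give no explanation for the change and do not show whether it would hold on another core.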